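The compounds below may be only part of what the source reports. "The series", "measured", "known", "first", "only" and "open" are said of these compounds alone.

Working notes on the series in a functional assay on the whole organism with Mus musculus as the target, in the writhing test, at a dose of 100 mg/kg by the intraperitoneal route; on this read-out higher numbers stand for more inhibition at the one dose given (going by the name of the read-out) and lower numbers for less inhibition.

Compound 1, `Brc1ccccc1COc1nc2ccccc2s1`, gives 51.9% in this assay. Compound 3, `Brc1ccc(OCCOc2nc3ccccc3s2)cc1`, gives 68.6% in this assay; of the two numbers, compound 1 is the lower, with compound 3 above it by a margin beyond the scatter. Compound 2, `Cc1ccc(COc2nc3ccccc3s2)cc1`, is reported in this assay as "not active" (no number reported), with no number.

Compound 4, `FC(F)(F)c1ccccc1COc1nc2ccccc2s1`, differs from compound 1 in one place: trifluoromethyl in place of bromo on an aromatic carbon. Among the compounds with values here, no measured pair shows this change, so there is nothing on which to size it. The step from compound 1 to compound 4 is expected to be a number 1.9 percentage points lower from compound 1 to compound 4 (within the scatter), within the scatter. For compound 4 the inhibition is estimated at 50%, in the range 30% to 70%.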

Compound 4, a percentage reported as inhibition, in the whole organism at one dose (the size of the read-out at that dose, not a potency): "not active" (no number reported)
The entry for compound 4 holds no number; the estimate stays without a comparison.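

Within the data shown here, compound 4 is entered in this assay without a number, so no step from compound 1 to compound 4 can be read. Nothing shown bears on this result. The compounds shown leave open how trifluoromethyl in place of bromo changes inhibition.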